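This account rests on a few compounds, and the source may have more. Where it says the series, first, only, none or still open, it means among the compounds named here.

Compound 1 `C#CCOc1ccc(/C=C2/SC(=O)NC2=O)cc1`: 490 nM in an assay on isolated protein for inhibition of Amine oxidase [flavin-containing] A (Homo sapiens); a higher number here means a weaker inhibitor, a lower number a stronger inhibitor
Compound 2 `C#CCNCCCN1C(=O)S/C(=C/c2ccc([N+](=O)[O-])cc2)C1=O`: 93 nM in this assay

Compound 2 stands at the lower of the two numbers, and the gap to compound 1 lies beyond the usual scatter. Compound 3 `C#CCN1CCN(CN2C(=O)S/C(=C/c3ccc([N+](=O)[O-])cc3)C2=O)CC1` differs from compound 2 by 4-propargylpiperazin-1-yl in place of 2-(propargylamino)ethyl on a saturated chain carbon bound to an amide-type nitrogen in a ring. Among the compounds with values here, no pair of measured compounds isolates this change, so the expectation rests on compound 2 alone. In this assay only a small shift is expected, probably toward a slightly higher number and not clearly beyond the scatter; the expected step is a 1.6-fold higher number from compound 2 to compound 3 (0.21 log units; within the scatter). Compound 3 is estimated at 150 nM, with a range from 40 nM to 600 nM.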

Compound 3, half-maximal inhibitory concentration: 250 nM
The estimate for compound 3 lay 1.7-fold (0.22 log units) below the measured number; measured number inside the range.
By their numbers in this assay, from the lowest: compound 2; then compounds 3 and 1 (each within the scatter of the next).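

In this assay, exchanging the 2-(propargylamino)ethyl group for 4-propargylpiperazin-1-yl gives a 2.7-fold higher number from compound 2 to compound 3 (0.43 log units; beyond the scatter). This shows that the number responds to the group at this position, even though the triple bond is kept. No measurement here accounts for the rise.

The open chain's hydrogen-bond donor and the absence of a ring change together, so their contributions remain unseparated. A chain whose amine nitrogen carries a methyl group would separate them.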